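Working notes on the shared core: step to compound 4

This account rests on a few compounds, and the source may have more. Where it says the series, first, only, none or still open, it means among the compounds named here.

Measured so far in a functional assay on MDA-MB-231 cells (Homo sapiens) for antiproliferative activity, read by MTT assay, with a stated time of 72 h, tested at 10 uM; on this read-out lower numbers stand for less inhibition and higher numbers for more inhibition at the one concentration tested (going by the name of the read-out):
Compound 1 `Fc1ccc(-c2nss/c2=N\c2ccccc2)cc1` gives 0%
Compound 2 `S=c1ssnc1-c1ccccc1` gives 0%
Compound 3 `O=[N+]([O-])c1ccc(-c2nssc2=S)cc1` gives 0%

Compound 3 stands level with compound 1 and compound 2 at the digits printed; its nearest neighbour on the numbers is compound 1, and its furthest is compound 2, both within the scatter of this assay. Within the data shown here, the only step measured, no change at the digits printed from compound 2 to compound 3 (within the scatter), shows no change within the scatter.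

Compound 4 `Fc1ccc(-c2nssc2=S)cc1` has not been measured. It differs from compound 3 as follows: fluoro in place of nitro on an aromatic carbon. Among the measured compounds shown here, the one measured step that bears on this change is the step from compound 2 to compound 3, which adds the nitro and gives no change in this assay; compound 4 removes that nitro again and so returns to the substitution of compound 1, which also sits at the same level as compound 2 and compound 3. For the measured compounds named here, no measured step has moved beyond the scatter.

Accordingly, for compound 4 no step beyond the scatter is expected, no change at the digits printed from compound 3 to compound 4 (within the scatter), and the value is estimated at 0%, with a range from 0% to 12%.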

Compound 4, a percentage reported as inhibition, at one concentration (the size of the read-out at that concentration, not a potency): 0%
Compound 4: the middle estimate sits on the measured number at the digits printed, within the range that was stated.
By their numbers in this assay, from the lowest: compounds 1, 2, 3 and 4 (each within the scatter of the next).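

In this assay the position on the six-membered aromatic ring of carbon only, para to a group of 6 heavy atoms, now carries hydrogen, nitro or fluoro on the same core, and the three compounds cannot be told apart. Fluoro in place of nitro gives no change at the digits printed from compound 3 to compound 4 (within the scatter) on this read-out, and fluoro in place of hydrogen gives no change at the digits printed from compound 2 to compound 4 (within the scatter) on the same read-out, so the fluoro, like the nitro before it, does not separate from the unsubstituted ring at the one concentration tested. No measurement at hand offers an explanation for this flat result.

From the compounds shown here alone, whether an amine or a carboxylic acid at this position would move the reading away from that of compound 4 (0%) remains open. Also open, going by these compounds, is whether a change elsewhere on the shared core, such as a longer chain, would give any inhibition beyond the scatter, and whether these compounds would differ at another concentration.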